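Dropping the Methoxy Group: Compound 3 to Compound 4

The compounds below may be only part of what the source reports. "The series", "measured", "known", "first", "only" and "open" are said of these compounds alone.

Compound 3 `COc1ccccc1NC1=CC(=O)c2c(nc3n2[C@H]2OC[C@@H](O)[C@H]2OC3)C1=O` has the lowest of the two numbers measured in a functional assay on MGC-803 cells (Homo sapiens) for inhibition, read by sulforhodamine B assay (a higher number here means a weaker inhibitor, a lower number a stronger inhibitor), giving 1670 nM. Compound 1 `CCCc1ccc(NC2=CC(=O)c3c(nc4n3[C@H]3OC[C@@H](O)[C@H]3OC4)C2=O)cc1` sits nearest, giving 1920 nM in this assay. Compound 2 `O=C1C(N2CCCCC2)=CC(=O)c2c1nc1n2[C@H]2OC[C@@H](O)[C@H]2OC1` gives only a limit in this assay, > 4000 nM. The change to compound 4 `O=C1C(Nc2ccccc2)=CC(=O)c2c1nc1n2[C@H]2OC[C@@H](O)[C@H]2OC1` is modest in size: hydrogen in place of methoxy on an aromatic carbon. Within the data shown here, two measured steps bear on it. The swap of one aryl group for another on the amine nitrogen, a 1.1-fold lower number from compound 1 to compound 3 (0.06 log units; within the scatter), stayed within the scatter, while the larger replacement an at least 2.3-fold lower number from compound 2 to compound 3 (0.37 log units; beyond the scatter) was at least modest. Removing the methoxy group is therefore expected to move this assay little, if at all. Compound 4 is expected at 1800 nM, within 900 nM to 3600 nM, a step of a 1.1-fold higher number from compound 3 to compound 4 (0.03 log units; within the scatter).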

Compound 4, half-maximal inhibitory concentration: 1830 nM
Estimate against measurement, compound 4: 1.0-fold (0.01 log units) below; measured number inside the range.
By their numbers in this assay, from the lowest: compounds 3, 4 and 1 (each within the scatter of the next). At a limit, above all of these: compound 2.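

Taking the methoxy group off gives a 1.1-fold higher number from compound 3 to compound 4 (0.04 log units; within the scatter), and taking the propyl group off gives a 1.0-fold lower number from compound 1 to compound 4 (0.02 log units; within the scatter), so in this assay the unsubstituted phenyl ring does as well as either substituted one. Anilino in place of piperidin-1-yl gives an at least 2.1-fold lower number from compound 2 to compound 4 (0.33 log units; beyond the scatter), so the aromatic amine holds up without any group on its ring. Compound 2 is recorded only as a limit, not as a number: the limit of > 4000 nM in this assay, at which 1 of the 4 values shown sits.

As far as these compounds go, whether a carboxylic acid or a chlorine on this ring would move the number stays open. So does the effect of a longer chain on the amine nitrogen.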